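The source may hold more compounds than are shown below. What is called first, only, known or untested is meant among the compounds shown, and "the series" means these compounds.

Measured compounds:
- Compound 1, `c1ccc2c(c1)CN[C@@H](CN(CC1CCNCC1)[C@H]1CCCc3cccnc31)C2`: 65 nM
- Compound 2, `c1ccc2c(c1)CN[C@@H](CN(CCCN1CCNCC1)[C@H]1CCCc3cccnc31)C2`: 17 nM
- Compound 3, `c1ccc2c(c1)CN[C@@H](CN(CC[C@@H]1CCCNC1)[C@H]1CCCc3cccnc31)C2`: 161 nM

In a functional assay on CCRF-CEM cells for antagonist activity at C-X-C chemokine receptor type 4 (Homo sapiens), read by calcium flux, with stated times of 25 min and 90 s (on this read-out higher numbers stand for weaker inhibition and lower numbers for stronger inhibition), compound 2 gives the lowest number of the three, with compound 1 nearest (a 3.8-fold lower number from compound 1 to compound 2 (0.58 log units; beyond the scatter)) and compound 3 furthest (a 9.5-fold higher number from compound 2 to compound 3 (0.98 log units; beyond the scatter)). Compound 4, `c1cnc2c(c1)CCC[C@@H]2N(CCCN1CCNCC1)Cc1nc2ccccc2s1`, keeps the side chain of compound 2 and changes the other arm of the amine: 1,3-benzothiazol-2-yl in place of 1,2,3,4-tetrahydroisoquinolin-3-yl on a saturated chain carbon bound to an amine nitrogen.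

Among the compounds with values here, none of the measured steps bears on this change. The steps of a 3.8-fold lower number from compound 1 to compound 2 (0.58 log units; beyond the scatter), a 2.5-fold higher number from compound 1 to compound 3 (0.39 log units; beyond the scatter) and a 9.5-fold higher number from compound 2 to compound 3 (0.98 log units; beyond the scatter) all vary the side chain, while the tetrahydroisoquinoline is kept in every measured compound. The exchange in compound 4 removes the only hydrogen-bond donor of the leaving group and brings in an aromatic bicycle, a change without precedent in this set, so the direction cannot be read from the data. Compound 4 is therefore expected to give a number not far from compound 2, with wide uncertainty: a 2.9-fold higher number from compound 2 to compound 4 (0.47 log units; beyond the scatter). The estimate for compound 4 in this assay is 50 nM, between 8 nM and 400 nM.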

Compound 4, half-maximal inhibitory concentration: 1200 nM
The estimate for compound 4 lay 24-fold (1.38 log units) below the measured number; the measured number lies above the stated range.
By their numbers in this assay, from the lowest: compound 2; then compound 1; then compound 3; then compound 4.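

In this assay, the exchange of 1,2,3,4-tetrahydroisoquinolin-3-yl for 1,3-benzothiazol-2-yl gives a 71-fold higher number from compound 2 to compound 4 (1.85 log units; beyond the scatter). This first change on the saturated chain carbon bound to an amine nitrogen outweighs the largest side-chain step among these compounds, a 9.5-fold higher number from compound 2 to compound 3 (0.98 log units; beyond the scatter), so in this small set the arm holding the tetrahydroisoquinoline counts for at least as much as the side chain. Nothing available explains the size of this step.

The exchange alters the ring, the hetero atoms, the hydrogen-bond donors and the defined stereocentre together, so the compounds shown cannot tell which of these matters, and a 1H-benzimidazol-2-yl or a 1,2,3,4-tetrahydroquinolin-2-yl in the same place remains an open case. As far as these compounds go, whether the step would be of similar size with the side chains of compound 1 or compound 3 also stays open.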